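Aryl amine variation on a shared core, compounds 1 to 3

The source may report more compounds than this note shows. Statements on the series, on what has been measured and on what is new or still open speak of the compounds shown alone.

Compound 1 `Cc1ccc(Nc2ncc(C(F)(F)F)c(N3Cc4cccc(N(C)S(C)(=O)=O)c4C3)n2)cc1C` gives > 20000 nM in an assay on Sf9 cells for inhibition of tyrosine-protein kinase receptor UFO (Homo sapiens), read by luminescence and ADP-Glo; a higher number here means a weaker inhibitor, a lower number a stronger inhibitor; this is a limit of the assay.
Compound 2 `COc1ccc(C(F)(F)F)cc1Nc1ncc(C(F)(F)F)c(N2Cc3cccc(N(C)S(C)(=O)=O)c3C2)n1` gives > 20000 nM in this assay; this too is a limit of the assay.

Going by the values given here, compound 2 therefore stands at a limit, and so does the only other measured compound. The step that the two limits leave unreadable from compound 1 to compound 2 cannot be read, and the limit of > 20000 nM in this assay, at which 2 of the 2 values shown sit, is the whole of the evidence on the measured compounds: both sit at the same limit, so no direction or size of effect of the aryl amine change can be taken from them.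

Compound 3 `COc1cc(Nc2ncc(C(F)(F)F)c(N3Cc4cccc(N(C)S(C)(=O)=O)c4C3)n2)c(OC)cc1Cl` carries the change (4-chloro-2,5-dimethoxyphenyl in place of 2-methoxy-5-(trifluoromethyl)phenyl on a nitrogen on an aromatic ring). Among the compounds with values here, the one measured step that bears on it is the unreadable one from compound 1 to compound 2, so no step size beyond the scatter can be expected from the data; the working assumption is that compound 3 stays at or near the limit where compounds 1 and 2 sit. Compound 3 is thus estimated at 30000 nM, within 8000 nM to 100000 nM, meaning an expected step that the limit leaves unreadable from compound 2 to compound 3.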

Compound 3, half-maximal inhibitory concentration: > 20000 nM
Compound 3: no number, only a limit (the forecaster's own chance of this, stated with the estimate: 80%); the middle value lies beyond the limit too.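

Compound 3 gives > 20000 nM in this assay, and this is a limit of the assay. Going by these compounds alone, no step among compound 1, compound 2 and compound 3 can be read: the limit of > 20000 nM in this assay, at which 3 of the 3 values shown sit. The compounds shown leave open whether any aryl amine on the shared core gives a measurable value in this assay, and how large the effect of changing it would be.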